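The source may report more compounds than this note shows. Statements on the series, on what has been measured and on what is new or still open speak of the compounds shown alone.

Of the compounds shown here, three sharing one core have been measured in a functional assay on MCF7 cells (Homo sapiens) for antiproliferative activity, read by MTT assay, with a stated time of 48 h; a lower number here means a stronger inhibitor, a higher number a weaker inhibitor. Compound 1 `COc1cc(-c2nnc3c(OC(C)C)cc(-c4ccc5[nH]ccc5c4)cn23)cc(OC)c1OC`, with an isopropyl group on an oxygen, gives 1020 nM, the lowest number of the set. Compound 2 `COc1cc(-c2nnc3c(OC4COC4)cc(-c4ccc5[nH]ccc5c4)cn23)cc(OC)c1OC` carries oxetan-3-yl on that oxygen and gives 2470 nM. That is a 2.4-fold higher number from compound 1 to compound 2 (0.38 log units; beyond the scatter). Compound 3 `COc1cc(-c2nnc3c(OC4CN(C(C)(C)C)C4)cc(-c4ccc5[nH]ccc5c4)cn23)cc(OC)c1OC`, with 1-(tert-butyl)azetidin-3-yl there, reaches only a limit of the assay, > 10000 nM. The change in that case is an at least 9.8-fold higher number from compound 1 to compound 3 (0.99 log units; beyond the scatter).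

Compound 4 `COc1cc(-c2nnc3c(OC(C)C)cc(-c4ccc5c(ccn5C)c4)cn23)cc(OC)c1OC` keeps the isopropyl group and differs elsewhere: methyl in place of hydrogen on an aromatic nitrogen. So 1H-indol-5-yl becomes 1-methyl-1H-indol-5-yl, with the new methyl on its nitrogen.

For the measured compounds named here, none of the measured steps touches that nitrogen. They all concern the group on the oxygen, and they show that compound 1 loses ground in this assay when that group is replaced, as in a 2.4-fold higher number from compound 1 to compound 2 (0.38 log units; beyond the scatter). They give no direct size for a change at the nitrogen. Going by the values given here, with no measured step at that place, no step beyond the scatter is expected in either direction, and the range has to stay wide. The estimated step is a 1.1-fold lower number from compound 1 to compound 4 (0.05 log units; within the scatter). For compound 4 the expected value is 900 nM, with an estimated range of 280 nM to 3000 nM.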

Compound 4, half-maximal inhibitory concentration: 204 nM
For compound 4 the middle estimate is 4.4-fold (0.64 log units) above the measured one, and the stated range ends above it.
By their numbers in this assay, from the lowest: compound 4; then compound 1; then compound 2. At a limit, above all of these: compound 3.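

The nitrogen of the 1H-indol-5-yl group turns out to be a place where a very small change matters: in this assay, methyl in place of hydrogen on this aromatic nitrogen gives a 5.0-fold lower number from compound 1 to compound 4 (0.70 log units; beyond the scatter), a step beyond the usual scatter. The earlier steps shown here from compound 1 all changed the group on the oxygen and all raised the number, so compound 1 had looked like the best point in the set, but compound 4 now sits lowest with 204 nM and the isopropyl group unchanged. For this pair, the hydrogen on the nitrogen is therefore not needed for a low number, and one added carbon atom is enough to move the result in the favourable direction.

Going by these compounds, it remains open whether an ethyl group, a longer chain or a chain ending in an amine on that nitrogen would lower the number further, and whether the same methyl would also lower the number when the oxygen carries the oxetan-3-yl group of compound 2. Why the methyl has this effect also remains open, as nothing measured here bears on the cause.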